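The source may hold more compounds than are shown below. What is called first, only, known or untested is meant among the compounds shown, and "the series" means these compounds.

Of the compounds shown here, three sharing one core have been tested in a functional assay on CWR22R cells (Homo sapiens) for inhibition, read by MTT assay; a lower number here means a stronger inhibitor of growth, a higher number a weaker inhibitor of growth. Compound 1 `CC1=C(/C=C/C(C)=C/C=C/C(C)=C\C(=O)Nc2ccc(O)cc2)C(C)(C)CCC1n1ccnc1` gives 3890 nM in this assay. Compound 2 `CC1=C(/C=C/C(C)=C/C=C/C(C)=C\C(=O)Nc2cccc(F)c2)C(C)(C)CCC1n1ccnc1` gives 2040 nM, and compound 3 `CC1=C(/C=C/C(C)=C/C=C/C(C)=C\C(=O)Nc2ccc(F)cc2)C(C)(C)CCC1n1ccnc1` gives 8120 nM. Compound 2 shows the lowest of the three numbers in this assay, although the step of a 1.9-fold lower number from compound 1 to compound 2 (0.28 log units; within the scatter) is within the scatter, so compounds 1 and 2 cannot be separated; the step of a 4.0-fold higher number from compound 2 to compound 3 (0.60 log units; beyond the scatter) lies beyond the scatter, and so does the step of a 2.1-fold higher number from compound 1 to compound 3 (0.32 log units; beyond the scatter).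

Compound 4 `CC1=C(/C=C/C(C)=C/C=C/C(C)=C\C(=O)NCc2ccccc2)C(C)(C)CCC1n1ccnc1` has not yet been measured. It differs from compound 2 in one place: benzyl in place of 3-fluorophenyl on an amide-type nitrogen. For the measured compounds named here, no measured step introduces benzyl on the amide-type nitrogen, so nothing bears on this change directly. The closest comparisons are the steps of a 1.9-fold lower number from compound 1 to compound 2 (0.28 log units; within the scatter) and a 4.0-fold higher number from compound 2 to compound 3 (0.60 log units; beyond the scatter), which also alter the group on that nitrogen and give modest changes in this assay. A modest step is therefore expected here, its direction uncertain, with a somewhat higher number considered a little more likely since compound 2 already sits at the low end. The expected step is a 2.0-fold higher number from compound 2 to compound 4 (0.29 log units; within the scatter). Compound 4 is estimated at 4000 nM in this assay, within a range from 1500 nM to 11000 nM.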

Compound 4, concentration for 50% growth inhibition: > 100000 nM
Compound 4 gave a limit, no number; the forecaster's own chance of this, stated with the estimate: 5%; at least 25-fold (1.39 log units) between middle value and limit.
By their numbers in this assay, from the lowest: compounds 2 and 1 (each within the scatter of the next); then compound 3. At a limit, above all of these: compound 4.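

Compound 4 gives no number in this assay, only a limit: the limit of > 100000 nM in this assay, at which 1 of the 4 values shown sits. The change keeps the same count of heavy atoms and one carbon-only aromatic ring, with no hydrogen-bond donors or acceptors on either group, yet the steps are large: an at least 49-fold higher number from compound 2 to compound 4 (1.69 log units; beyond the scatter), an at least 12-fold higher number from compound 3 to compound 4 (1.09 log units; beyond the scatter) and an at least 25-fold higher number from compound 1 to compound 4 (1.41 log units; beyond the scatter). On this amide-type nitrogen, 3-fluorophenyl, 4-fluorophenyl and 4-hydroxyphenyl all give measurable numbers and benzyl does not, so the position tolerates far less than the modest earlier steps suggested.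

Benzyl is the only group of its kind shown and the change also removes the fluorine, so a 3-fluorobenzyl group would be needed to tell whether the fluorine's absence plays a part, and unsubstituted phenyl or a longer 2-phenylethyl chain would show how narrow the tolerance on this nitrogen really is. As far as these compounds go, since each of the three steps rests on a limit, their true sizes also stay open.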